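Moving the Methyl Around a Pyrazole on an Amide Nitrogen

This account rests on a few compounds, and the source may have more. Where it says the series, first, only, none or still open, it means among the compounds named here.

Three measured compounds share a common core. Compound 2 `Cc1ccc(OCC(=O)N(Cc2cccs2)c2ccnn2C)cc1` gives 422 nM in an assay on HEK293 cells for agonist activity at transient receptor potential cation channel subfamily M member 8 (Homo sapiens), read by fluorescence and calcium flux, with a stated time of 15 min (on this read-out lower numbers stand for an effect already at smaller amounts and higher numbers for an effect only at larger amounts of compound), the lowest of the two numbers reported. Compound 1 `CCCc1ccc(OCC(=O)N(CC)Cc2cccs2)cc1` gives 1810 nM, a gap from compound 2 that lies beyond the usual scatter. Compound 3 `CCN(Cc1cccs1)C(=O)COc1ccc(C(=O)O)cc1` was reported as "not active" (no number reported), with no number given. Compound 4 `Cc1ccc(OCC(=O)N(Cc2cccs2)c2c[nH]nc2C)cc1` has not yet been measured. It differs from compound 2 in one place: 3-methyl-1H-pyrazol-4-yl in place of 1-methyl-1H-pyrazol-5-yl on an amide-type nitrogen. For the measured compounds named here, no measured pair shows a change of this kind, so there is no direct guide for its size. The step of a 1.7-fold higher number from compound 2 to compound 4 (0.22 log units; within the scatter) is expected to stay close to the usual scatter, at most a slight weakening. In this assay compound 4 is therefore estimated at 700 nM, with a range from 200 nM to 2500 nM.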

Compound 4, half-maximal effective concentration: 0.4 nM
Compound 4: the middle estimate sits 1800-fold (3.24 log units) above what was measured; measured number below the stated range.
By their numbers in this assay, from the lowest: compound 4; then compound 2; then compound 1.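

The change of 3-methyl-1H-pyrazol-4-yl in place of 1-methyl-1H-pyrazol-5-yl on the amide-type nitrogen gives a 1100-fold lower number from compound 2 to compound 4 (3.02 log units; beyond the scatter) in this assay. So at this position, the way the same atoms are joined can change the number greatly, which the earlier compounds could not show. The entering group also carries a hydrogen-bond donor that the leaving group lacks, but no measurement here links the step to that difference or to any other cause.
On these data alone, it remains open how a phenyl group or an unsubstituted pyrazolyl group in this place would compare with compound 4.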